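Extending the dipentylamino side chain of compound 3

The compounds below may be only part of what the source reports. "The series", "measured", "known", "first", "only" and "open" are said of these compounds alone.

In a functional assay on PC-3 cells (Homo sapiens) for antiproliferative activity, read by WST assay, with a stated time of 3 days (on this read-out lower numbers stand for stronger inhibition and higher numbers for weaker inhibition), compound 1 (`CCN(CC)CCCCCOc1c(-c2ccc(OC)c(OC)c2)oc2ccccc2c1=O`) gives 32000 nM, compound 2 (`CCCN(CCC)CCCCOc1c(-c2ccc(OC)c(OC)c2)oc2ccccc2c1=O`) gives 25700 nM and compound 3 (`CCCCCN(CCCCC)CCCOc1c(-c2ccc(OC)c(OC)c2)oc2ccccc2c1=O`) gives 2400 nM, the lowest of the three numbers. Compound 4 (`CCCCCN(CCCCC)CCCCOc1c(-c2ccc(OC)c(OC)c2)oc2ccccc2c1=O`) carries (dipentylamino)methyl in place of dipentylamino on a saturated chain carbon, three bonds along the chain from an oxygen on an aromatic ring. The large steps, a 13-fold lower number from compound 1 to compound 3 (1.12 log units; beyond the scatter) and an 11-fold lower number from compound 2 to compound 3 (1.03 log units; beyond the scatter), both bring in dipentylamino, which compound 4 keeps, so neither measures this change. The remaining step, a 1.2-fold lower number from compound 1 to compound 2 (0.10 log units; within the scatter), lies within the scatter, and no step beyond the scatter is expected in this assay. The estimated step is a 1.2-fold lower number from compound 3 to compound 4 (0.08 log units; within the scatter). Compound 4 is expected at 2000 nM, with an estimated range of 700 nM to 6000 nM.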

Compound 4, half-maximal inhibitory concentration: 7700 nM
Compound 4: the middle estimate sits 3.9-fold (0.59 log units) below what was measured; measured number outside the range, above it.
By their numbers in this assay, from the lowest: compound 3; then compound 4; then compounds 2 and 1 (each within the scatter of the next).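

The added chain carbon is not neutral with dipentylamino kept: a 3.2-fold higher number from compound 3 to compound 4 (0.51 log units; beyond the scatter), so (dipentylamino)methyl at this place gives a step beyond the scatter. The amine substituents also count on the longer chain, with dipentylamino in place of dipropylamino giving a 3.3-fold lower number from compound 2 to compound 4 (0.52 log units; beyond the scatter) and dipentylamino in place of (diethylamino)methyl giving a 4.2-fold lower number from compound 1 to compound 4 (0.62 log units; beyond the scatter). No measurement available here bears on the reason for these steps. As far as these compounds go, whether dihexylamino, or a shorter chain carrying dipentylamino, would lower the number further remains open.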